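Chloro Analogue of an Inactive Pair

The source may report more compounds than this note shows. Statements on the series, on what has been measured and on what is new or still open speak of the compounds shown alone.

Compounds measured so far:
compound 1 `CN1C(=O)C2(C(C#N)=C(N)Oc3cc4oc(-c5ccccc5)cc(=O)c4c(O)c32)c2ccccc21`; in a functional assay on PC-3 cells (Homo sapiens) for antiproliferative activity, read by MTT assay, with a stated time of 48 h (on this read-out higher numbers stand for weaker inhibition and lower numbers for stronger inhibition), compound 1 gives > 50000 nM, a limit of the assay
compound 2 `Cc1ccc2c(c1)C1(C(=O)N2C)C(C#N)=C(N)Oc2cc3oc(-c4ccccc4)cc(=O)c3c(O)c21`; in this assay compound 2 gives > 50000 nM, a limit of the assay

Compound 1 stands only at a limit of the assay, not at a number. Compound 2 stands at the same limit. Going by the values given here, the one step with a measurement, a step that the two limits leave unreadable from compound 1 to compound 2, is therefore unreadable in size and direction. Both values sit at the limit of > 50000 nM in this assay, at which 2 of the 2 values shown sit, so the shared core gives no foothold for reading substituent effects.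

Compound 3 `CN1C(=O)C2(C(C#N)=C(N)Oc3cc4oc(-c5ccccc5)cc(=O)c4c(O)c32)c2cccc(Cl)c21` differs from compound 1 by chloro in place of hydrogen on an aromatic carbon. Among the compounds with values here, the only measured step that bears on it is the unreadable methyl step, which gives no guidance on size or direction. Compound 3 is therefore expected to stay at or near the limit of this assay. The estimate for compound 3 is 60000 nM, ranging from 15000 nM to 250000 nM. The expected step is a step that the limit leaves unreadable from compound 1 to compound 3.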

Compound 3, half-maximal inhibitory concentration: > 50000 nM
Compound 3: a limit, no number; the forecaster's own chance of this, stated with the estimate: 80%; the middle value is on the limit's open side.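

In this assay compound 3 gives > 50000 nM as a limit, not a number. Neither the step from compound 1 to compound 3 nor that from compound 1 to compound 2 can be read: the limit of > 50000 nM in this assay, at which 3 of the 3 values shown sit. The compounds shown leave open whether any change to the shared core gives a measured number in this assay rather than a limit.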